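This account rests on a few compounds, and the source may have more. Where it says the series, first, only, none or still open, it means among the compounds named here.

Compound 1 `O=C(O)CCc1nc2ccccc2nc1OCc1ccccn1` was tested in an assay for displacement of a labelled ligand from protein deacetylase HDAC6 (Homo sapiens), read by fluorescence polarization, with a stated time of 10 min (on this read-out lower numbers stand for stronger inhibition and higher numbers for weaker inhibition), and gave 270000 nM. For the measured compounds named here, the only other compound measured there, compound 2 `Cc1cccc(OCCOc2nc3ccccc3nc2CCC(=O)O)c1`, gave 180000 nM, a number that lies within the usual scatter of the value of compound 1, so the two cannot be told apart. Compound 3 `Cn1ccnc1COc1nc2ccccc2nc1CCC(=O)O` has not yet been measured. It differs from compound 1 in one place: 1-methyl-1H-imidazol-2-yl in place of pyridin-2-yl on a saturated chain carbon bound to an oxygen on an aromatic ring. Going by the values given here, with no measured step to lean on, the expected change in this assay from compound 1 to compound 3 is a 1.1-fold lower number from compound 1 to compound 3 (0.03 log units; within the scatter), none beyond the scatter in either direction. Compound 3 is thus estimated at 250000 nM, with a range from 100000 nM to 600000 nM.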

Compound 3, half-maximal inhibitory concentration: 140000 nM
Compound 3: the middle estimate sits 1.8-fold (0.25 log units) above what was measured; measured number inside the range.
By their numbers in this assay, from the lowest: compounds 3, 2 and 1 (each within the scatter of the next).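

In this assay, 1-methyl-1H-imidazol-2-yl in place of pyridin-2-yl on a saturated chain carbon bound to an oxygen on an aromatic ring gives a 1.9-fold lower number from compound 1 to compound 3 (0.29 log units; within the scatter), so at this position a five-membered aromatic ring with 2 hetero atoms can stand for a six-membered one with no change that can be told from the scatter. No available data bear on this result.

The compounds shown leave open whether an amine in place of pyridin-2-yl would give a number beyond the scatter of compound 1. They also leave open what a hydroxamic acid in place of the carboxylic acid would do.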